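A few compounds are considered here, and "the series" means these few. Any claim that something is new, unique, unknown or untested is made for them only; others in the source may bear on it.

Measured compounds:
compound 1, `O=C(NCCCCl)Nc1ccc(I)cc1`: 90000 nM
compound 2, `O=C(CCl)Nc1ccc(I)cc1`: 9700 nM

For the measured compounds named here, in a functional assay on HT-29 cells (Homo sapiens) for antiproliferative activity, with a stated time of 48 h (on this read-out lower numbers stand for stronger inhibition and higher numbers for weaker inhibition), compound 2 gives 9700 nM, the lower of the two numbers so far; compound 1 gives 90000 nM, and the step of a 9.3-fold lower number from compound 1 to compound 2 (0.97 log units; beyond the scatter) separates them. Compound 3, `O=C(CCCl)Nc1ccc(I)cc1`, differs from compound 2 by chloromethyl in place of chloro on a saturated chain carbon bound to a carbonyl carbon. Going by the values given here, only one measured step speaks to this change, a 9.3-fold lower number from compound 1 to compound 2 (0.97 log units; beyond the scatter), which replaced the (3-chloropropyl)amino group with the short chloromethyl; compound 3 lengthens that chain again while keeping the amide. Because the lengthening in compound 3 only partly reverses what a 9.3-fold lower number from compound 1 to compound 2 (0.97 log units; beyond the scatter) removed, a modest move back toward the number of compound 1 is expected rather than a full return. Compound 3 is therefore estimated at 30000 nM in this assay, within 8000 nM to 100000 nM, meaning an expected 3.1-fold higher number from compound 2 to compound 3 (0.49 log units; beyond the scatter) that would lie beyond the scatter.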

Compound 3, half-maximal inhibitory concentration: 18000 nM
Beside the measured number, compound 3's estimate is 1.7-fold (0.22 log units) above it; the range from low to high includes it.
By their numbers in this assay, from the lowest: compounds 2 and 3 (each within the scatter of the next); then compound 1.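

In this assay, adding a carbon to the chain on the carbonyl carbon, chloromethyl to 2-chloroethyl, gives a 1.9-fold higher number from compound 2 to compound 3 (0.27 log units; within the scatter), so this change leaves no readable difference between the two amides. The other new step, a 5.0-fold lower number from compound 1 to compound 3 (0.70 log units; beyond the scatter), shows that replacing (3-chloropropyl)amino with 2-chloroethyl on the carbonyl carbon still gives a difference beyond the scatter, so the earlier gap between the (3-chloropropyl)amino compound and the chloromethyl amide does not rest on that one added carbon alone. Nothing shown accounts for either step.

The compounds shown leave open whether a longer chain, such as 3-chloropropyl on the same carbonyl carbon, would stay within the scatter of these two amides. They also leave open what a bromine or a hydroxyl in place of the chlorine would do at the chain end.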